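Paw edema series: a chloro added to compound 3

The source may report more compounds than this note shows. Statements on the series, on what has been measured and on what is new or still open speak of the compounds shown alone.

Measured so far in a functional assay on the whole organism (strain albino) for inhibition, with Rattus norvegicus as the target, read by paw edema, with a stated time of 1 h, at a dose of 100 mg/kg by the oral route; on this read-out lower numbers stand for less inhibition and higher numbers for more inhibition at the one dose given (going by the name of the read-out):
compound 1 `N#Cc1c(-c2ccc(Cl)cc2)nc(SCC(=O)Nn2c(COc3ccc(Cl)cc3Cl)nc3ccccc3c2=O)[nH]c1=O` gives 63.6%.
compound 2 `O=C(CSc1nc(-c2ccc(O)cc2)c(C(=O)O)c(=O)[nH]1)Nn1c(COc2ccc(Cl)cc2Cl)nc2ccccc2c1=O` gives 36.4%.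
compound 3 `N#Cc1c(Cl)nc(SCC(=O)Nn2c(COc3ccc(Cl)cc3Cl)nc3ccccc3c2=O)nc1-c1ccccc1` gives 60%.

Compound 3 stands second highest of the three numbers. Its nearest neighbour is compound 1, whose number is higher by an amount within the scatter, so no order between compound 3 and compound 1 can be read. Compound 2 lies furthest, lower by a gap beyond the scatter. Among the measured compounds shown here, no two measured compounds differ in one place only, so no single-point step is available.

Compound 4 `N#Cc1c(Cl)nc(SCC(=O)Nn2c(COc3ccc(Cl)cc3Cl)nc3ccccc3c2=O)nc1-c1ccc(Cl)cc1` differs from compound 3 by chloro in place of hydrogen on an aromatic carbon. Read one bond further out, phenyl becomes 4-chlorophenyl. Compound 1 also carries a 4-chlorophenyl group and gives 63.6%, a number within the scatter of compound 3. On that basis the step from compound 3 to compound 4 is expected to be a number 3 percentage points higher from compound 3 to compound 4 (within the scatter), not beyond the scatter, upward if anything. Compound 4 is estimated at 63%, with a range from 48% to 78%.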

Compound 4, a percentage reported as inhibition, in the whole organism at one dose (the size of the read-out at that dose, not a potency): 63.6%
The estimate for compound 4 lay 0.6 percentage points below the measured number; the range from low to high includes it.
By their numbers in this assay, from the lowest: compound 2; then compounds 3, 1 and 4 (each within the scatter of the next).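

Working notes on the para position of the phenyl ring: in this assay, chloro in place of hydrogen on an aromatic carbon gives a number 3.6 percentage points higher from compound 3 to compound 4 (within the scatter). Among the compounds shown here, this is the first single-point step, and it shows that phenyl to 4-chlorophenyl on this scaffold leaves the read-out within the usual scatter at the one dose given, so no gain or loss can be assigned to the chloro. The read-out measures the size of the effect at that dose and does not give a potency, and nothing at hand bears on why the step is this size.

On these data alone, whether an amine, a methoxy group or a carboxylic acid at the same position would also stay within the scatter remains open. Also open, as far as these compounds go, is whether the same step would hold on a core carrying a different group in place of the ring chloro or the nitrile.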